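Replacing the Aryl Group on the Carboxylic Acid

The source may report more compounds than this note shows. Statements on the series, on what has been measured and on what is new or still open speak of the compounds shown alone.

Compound 1 `CCOC(=O)C1=Cc2ccccc2OC1(OCc1cc(-c2ccc(OC)cc2)no1)C(F)(F)F`: in a functional assay on DU-145 cells (Homo sapiens) for inhibition, read by MTT assay, with a stated time of 24 h (on this read-out higher numbers stand for weaker inhibition and lower numbers for stronger inhibition), compound 1 stands at the assay limit > 150000 nM, which is not a number.
Compound 2 `CCOC(=O)C1=Cc2ccccc2OC1(OCc1cc(-c2cccc(C(F)(F)F)c2)no1)C(F)(F)F`: in this assay compound 2 gives 57300 nM.
Compound 3 `O=C(O)C1=Cc2ccccc2OC1(OCc1cc(-c2cccc(C(F)(F)F)c2)no1)C(F)(F)F`: in this assay compound 3 gives 155000 nM.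

Compound 3 differs from compound 2 by hydrogen in place of ethyl on an oxygen next to a carbonyl group, and this gives a 2.7-fold higher number from compound 2 to compound 3 (0.43 log units; beyond the scatter). From the compounds shown here alone, compound 1 differs from compound 2 by 4-methoxyphenyl in place of 3-(trifluoromethyl)phenyl on an aromatic carbon, giving an at least 2.6-fold higher number from compound 2 to compound 1 (0.41 log units; beyond the scatter); the full size of that step is unknown because of the limit of > 150000 nM in this assay, at which 1 of the 3 values shown sits. Compound 4 `COc1ccc(-c2cc(COC3(C(F)(F)F)Oc4ccccc4C=C3C(=O)O)on2)cc1` is not yet measured. It differs from compound 3 by 4-methoxyphenyl in place of 3-(trifluoromethyl)phenyl on an aromatic carbon, the same change as from compound 2 to compound 1, at a place described in identical words. Since compound 3 already gives 155000 nM, a repeated step of the size seen from compound 2 to compound 1 is expected to carry compound 4 still further in the same direction, with an estimated 2.6-fold higher number from compound 3 to compound 4 (0.41 log units; beyond the scatter). Compound 4 is therefore estimated at 400000 nM.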

Compound 4, half-maximal inhibitory concentration: 42000 nM
Compound 4: the middle estimate sits 9.5-fold (0.98 log units) above what was measured; the measured number lies below the stated range.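

Neither change carries over from one core to the other in this assay: on the carboxylic acid, 4-methoxyphenyl in place of 3-(trifluoromethyl)phenyl gives a 3.7-fold lower number from compound 3 to compound 4 (0.57 log units; beyond the scatter), the opposite direction to the same change on the ethyl ester, as these steps show: the same change on two cores in this assay, an at least 2.6-fold higher number (0.41 log units; beyond the scatter) from compound 2 to compound 1 and a 3.7-fold lower number (0.57 log units; beyond the scatter) from compound 3 to compound 4, at least 9.6-fold (0.98 log units) apart, beyond the scatter of two such steps Hydrogen in place of ethyl likewise gives an at least 3.5-fold lower number from compound 1 to compound 4 (0.55 log units; beyond the scatter), opposite to its earlier step: the same change on two cores in this assay, a 2.7-fold higher number (0.43 log units; beyond the scatter) from compound 2 to compound 3 and an at least 3.5-fold lower number (0.55 log units; beyond the scatter) from compound 1 to compound 4, at least 9.6-fold (0.98 log units) apart, beyond the scatter of two such steps Compound 1 sits at > 150000 nM, a limit and not a number, so the reversal is shown in direction but not in full size, and nothing here shows why it occurs: the limit of > 150000 nM in this assay, at which 1 of the 4 values shown sits.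

The compounds shown leave open whether the reversal also holds for other aryl groups, such as 4-chlorophenyl or unsubstituted phenyl. They also leave open what happens with an amide in place of the carboxylic acid.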